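Two Hydroxyphenyl Groups, One Shift in Position

The compounds below may be only part of what the source reports. "The series", "measured", "known", "first", "only" and "open" are said of these compounds alone.

Compound 1 `Oc1cccc(-c2cc(-c3ccc(C(F)(F)F)cc3)cc(-c3cccc(O)c3)n2)c1`: > 50000 nM
Compound 2 `Oc1ccc(-c2cc(-c3ccccc3C(F)(F)F)cc(-c3cccc(O)c3)n2)cc1`: 5740 nM
Compound 3 `Oc1ccc(-c2cc(-c3ccc(C(F)(F)F)cc3)cc(-c3cccc(O)c3)n2)cc1`: 6440 nM

In a functional assay on HCT-15 cells (Homo sapiens) for inhibition (on this read-out higher numbers stand for weaker inhibition and lower numbers for stronger inhibition), compound 1 reaches only a limit of the assay, not a number: > 50000 nM, as shown by the limit of > 50000 nM in this assay, at which 1 of the 3 values shown sits. Compound 3 gives 6440 nM and compound 2 gives 5740 nM, and the step of a 1.1-fold higher number from compound 2 to compound 3 (0.05 log units; within the scatter) lies within the scatter. The change 4-hydroxyphenyl in place of 3-hydroxyphenyl on an aromatic carbon gave an at least 7.7-fold lower number from compound 1 to compound 3 (0.89 log units; beyond the scatter). Compound 4 `Oc1ccc(-c2cc(-c3ccccc3C(F)(F)F)cc(-c3ccc(O)cc3)n2)cc1` is not yet measured and differs from compound 2 by 4-hydroxyphenyl in place of 3-hydroxyphenyl on an aromatic carbon. The surroundings differ, with the group sitting meta to a 2-(trifluoromethyl)phenyl group and meta to a 4-hydroxyphenyl group rather than meta to a 3-hydroxyphenyl group and meta to a 4-(trifluoromethyl)phenyl group, so this is the same kind of change, not the same change. How the cores of compound 1 and compound 2 differ is not broken down here. Compound 4 is expected to show a 2.9-fold lower number from compound 2 to compound 4 (0.46 log units; beyond the scatter), a more cautious expectation than the earlier step of an at least 7.7-fold lower number from compound 1 to compound 3 (0.89 log units; beyond the scatter) because that step was measured only against a limit (the limit of > 50000 nM in this assay, at which 1 of the 3 values shown sits). Compound 4 is estimated at 2000 nM, between 500 nM and 8000 nM.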

Compound 4, half-maximal inhibitory concentration: > 50000 nM
Compound 4 ended at the assay's limit; the forecaster's own chance of this, stated with the estimate: 2%; middle value at least 25-fold (1.39 log units) from the limit.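

On the core of compound 2, the swap of 3-hydroxyphenyl for 4-hydroxyphenyl in this assay gave an at least 8.7-fold higher number from compound 2 to compound 4 (0.94 log units; beyond the scatter). Compound 4 reached only a limit of the assay, not a number: > 50000 nM. So the change did not carry from one core to the other, even in direction, though these two cores alone show neither why this happens nor how large either step truly is: the same change on two cores in this assay, an at least 7.7-fold lower number (0.89 log units; beyond the scatter) from compound 1 to compound 3 and an at least 8.7-fold higher number (0.94 log units; beyond the scatter) from compound 2 to compound 4, at least 67-fold (1.83 log units) apart, beyond the scatter of two such steps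

Going by these compounds, whether a third core would follow compound 1 or compound 2 remains open. Also open, on these data alone, is whether an amine or a carboxylic acid in place of the hydroxyl group would keep the inhibition seen with compound 2 and compound 3.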